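This account rests on a few compounds, and the source may have more. Where it says the series, first, only, none or still open, it means among the compounds named here.

Compound 3 `COc1ccc(C(=O)O)cc1OCCCCOc1ccc(C(=O)CC2CCCC2)c(O)c1C` gives 425 nM in an assay on HEK293 cells for positive allosteric modulation of metabotropic glutamate receptor 2 (Rattus norvegicus), read by thallium flux, with a stated time of 2.5 min; a higher number here means that more compound is needed for the effect, a lower number that less compound is needed. Among the three measured compounds it stands second highest: compound 2 `Cc1c(OCCCCOc2cccc(C(=O)O)c2)ccc(C(=O)CC2CCCC2)c1O` gives 451 nM, and a 1.1-fold lower number from compound 2 to compound 3 (0.03 log units; within the scatter), while compound 1 `CCC(=O)c1ccc(OCCCCOc2cc(C(=O)O)ccc2OC)c(C)c1O` gives 162 nM, and a 2.6-fold higher number from compound 1 to compound 3 (0.42 log units; beyond the scatter). Compound 4 `COc1ccc(C(=O)O)cc1OCCCCOc1ccc(C(=O)CC(C)C)c(O)c1C` differs from compound 3 by isopropyl in place of cyclopentyl on a saturated chain carbon bound to a carbonyl carbon. Within the data shown here, only one measured step touches this place, the one from compound 1 to compound 3, where cyclopentyl replaced methyl and the number rose modestly. Removing the cyclopentyl again, in favour of isopropyl, would be expected to undo part of that rise, so a modest move toward a lower number in this assay is expected, though it may stay within the scatter. The step of a 1.5-fold lower number from compound 3 to compound 4 (0.18 log units; within the scatter) is the expected outcome. Compound 4 is expected to give 280 nM, with a range of 140 nM to 560 nM.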

Compound 4, half-maximal effective concentration: 155 nM
Estimate against measurement, compound 4: 1.8-fold (0.26 log units) above, within the range that was stated.
By their numbers in this assay, from the lowest: compounds 4 and 1 (each within the scatter of the next); then compounds 3 and 2 (each within the scatter of the next).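

In this assay, the change on a saturated chain carbon bound to a carbonyl carbon gives a 2.7-fold lower number from compound 3 to compound 4 (0.44 log units; beyond the scatter) when isopropyl takes the place of cyclopentyl. Isopropyl and methyl at this place cannot be told apart, with a 1.0-fold lower number from compound 1 to compound 4 (0.02 log units; within the scatter), so among these compounds only cyclopentyl goes with the higher number. Nothing available explains this difference. The compounds shown leave open whether the ring itself or the carbon count goes with that higher number. A straight pentyl chain or a cyclobutyl group at this place could separate the two.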